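The source may report more compounds than this note shows. Statements on the series, on what has been measured and on what is new or still open speak of the compounds shown alone.

Measured compounds in a functional assay on HepG2 cells (Homo sapiens) for inhibition, read by MTT assay, with a stated time of 72 h; a higher number here means a weaker inhibitor, a lower number a stronger inhibitor:

Compound 1, `C#CCSc1nc(NCCC#N)c2ccncc2n1` — compound 1 gives > 80000 nM, which is a limit of the assay and not a number.

Compound 2, `C#CCSc1nc(Nc2ccccc2Cl)c2ccncc2n1` — compound 2 gives 17200 nM.

Going by the values given here, compound 2 therefore holds the only actual number in this assay; the other value shown for this series, that of compound 1, is a limit (the limit of > 80000 nM in this assay, at which 1 of the 2 values shown sits). Among the compounds with values here, the single measured step runs between these two: an at least 4.6-fold lower number from compound 1 to compound 2 (0.66 log units; beyond the scatter), where the whole group on the ring nitrogen was exchanged.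

Compound 3, `C#CCSc1nc(Nc2ccc(Cl)cc2Cl)c2ccncc2n1`, keeps the shared core and the 2-chlorophenyl of compound 2 and differs only at one point: chloro in place of hydrogen on an aromatic carbon. Within the data shown here, no measured step in this set adds a second chloro to that phenyl ring, so the step from compound 1 to compound 2, which swaps 2-cyanoethyl for 2-chlorophenyl, bears on it only indirectly, showing that the aryl group on that nitrogen is where the number moved. The expected step in this assay, a 1.6-fold lower number from compound 2 to compound 3 (0.19 log units; within the scatter), is small, with a weakly improving direction but within the usual scatter. Compound 3 is estimated at 11000 nM, with a range from 4000 nM to 30000 nM.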

Compound 3, half-maximal inhibitory concentration: 11000 nM
The estimate for compound 3 equals the measured number at the digits printed, and the stated range covers the measured number.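

In this assay, going by these compounds alone, the added chloro gives a 1.6-fold lower number from compound 2 to compound 3 (0.19 log units; within the scatter), and this is the first reading of a change on the phenyl ring itself, since the earlier step exchanged the whole group on the nitrogen. At this carbon, para to a large group and meta to a chloro group, a chloro in place of hydrogen leaves compound 2 and compound 3 within the usual scatter of each other, so the two cannot be told apart in this assay, and the place tolerates the chloro without a measurable loss, although one substitution cannot show a gain. Nothing measured here bears on a cause for this step.

What the compounds shown leave open is whether a different group at this same carbon, such as a methoxy group, an amine or a carboxylic acid, would carry the number beyond the scatter in either direction. Going by these compounds, it also remains open whether a longer chain in place of the propargyl group on the sulfur would matter more than any change on the phenyl ring.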